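The compounds below may be only part of what the source reports. "The series", "measured", "known", "first", "only" and "open" are said of these compounds alone.

Measured so far in an assay on isolated protein for binding affinity to Neuropeptide Y receptor type 1 (Homo sapiens); a higher number here means a weaker inhibitor, a lower number a stronger inhibitor:
compound 1 `Clc1ccc(OCc2nc3ccccc3n2CCCN2CCCCC2)cc1` gives 7020 nM
compound 2 `Clc1ccc(OCc2nc3c(OCCCC4CCNCC4)cccc3n2CCCC2CCCNC2)cc1` gives 152 nM
compound 3 `Oc1cccc2c1nc(COc1ccc(Cl)cc1)n2CCCC1CCCNC1` gives 5300 nM

Compound 1 has the highest number of the three in this assay. Against compound 3 the gap is within the scatter, so the two cannot be ordered; against compound 2 the gap is large, with compound 2 giving the far lower number.

Among the measured compounds shown here, the only measured single step is a 35-fold higher number from compound 2 to compound 3 (1.54 log units; beyond the scatter). It concerns the oxygen substituent on the aromatic ring and does not touch the chain on the aromatic nitrogen, so it does not bear on the change considered here.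

Compound 4 `Clc1ccc(OCc2nc3ccccc3n2CCCC2CCNCC2)cc1` differs from compound 1 by piperidin-4-yl in place of piperidin-1-yl on a saturated chain carbon, three bonds along the chain from an aromatic nitrogen. For the measured compounds named here, no measured pair isolates this rearrangement. Compound 3 carries a chain with a ring bearing the same kind of nitrogen as in compound 4 and gives a number within the scatter of compound 1, which is the nearest guide. The step is therefore expected to be small, with no confident direction: a 1.4-fold lower number from compound 1 to compound 4 (0.15 log units; within the scatter) is estimated, and compound 4 is expected to give 5000 nM with a range of 1500 nM to 15000 nM.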

Compound 4, inhibition constant: 980 nM
The estimate for compound 4 lay 5.1-fold (0.71 log units) above the measured number, and the stated range ends above it.
By their numbers in this assay, from the lowest: compound 2; then compound 4; then compounds 3 and 1 (each within the scatter of the next).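

In this assay, the rearrangement gives a 7.2-fold lower number from compound 1 to compound 4 (0.86 log units; beyond the scatter), so at this chain position the way the ring is attached affects the number even though the atoms stay the same. The change from piperidin-1-yl to piperidin-4-yl leaves the ring size and heavy-atom composition as they were, while the count of hydrogen-bond donors goes from none to one. No measurement at hand accounts for the step.

Going by these compounds, whether the step follows the added donor or the new place of the ring nitrogen along the chain stays open, and a methyl group on the ring nitrogen of piperidin-4-yl would help separate the two. Also open, on these data alone, is how the step depends on chain length, which a 2-(piperidin-4-yl)ethyl chain would test.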